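The compounds below may be only part of what the source reports. "The series", "measured", "known", "first", "only" and "open" are said of these compounds alone.

Measured compounds:
Compound 1, `CNCc1cc(-c2ccccc2)n(S(=O)(=O)c2ccc(C)cc2)c1`: 66%
Compound 2, `CNCc1cc(-c2cncnc2)n(S(=O)(=O)c2ccccc2)c1`: "not determined" (no result reported)
Compound 3, `CNCc1cc(-c2cccnc2Cl)n(S(=O)(=O)c2cccnc2)c1`: 92%

The account follows the step from compound 3 to compound 4. In a functional assay on the whole organism (strain Jcl:SD) for inhibition, with Rattus norvegicus as the target, with stated times of 3 min and 3 h, at a dose of 1 mg/kg by the intravenous route (a lower number here means less inhibition, a higher number more inhibition at the dose given (going by the name of the read-out)), compound 3 gives 92% and stands highest of the two numbers that exist. Its nearest neighbour is compound 1, which in this assay gives 66%, a gap that lies beyond the usual scatter of repeated measurements, so compound 3 does stand above compound 1. Compound 2 has no result in this assay, so nothing can be said about where it falls.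

Compound 4, `CNCc1cc(-c2ncccc2C)n(S(=O)(=O)c2cccnc2)c1`, has not yet been measured. It differs from compound 3 in one place: 3-methylpyridin-2-yl in place of 2-chloropyridin-3-yl on an aromatic carbon. Among the compounds with values here, no step between two measured compounds matches that change, so the direction of the effect has to be taken from the two numbers alone. Within the data shown here, both numbers known so far are in the upper part of the scale, and the change keeps a six-membered aromatic ring with one hetero atom in the same place, so compound 4 is expected to stay in that upper region, with a modest drop that may not exceed the scatter: the estimated step is a number 12 percentage points lower from compound 3 to compound 4 (beyond the scatter). Compound 4 is therefore estimated at 80%, within a range from 55% to 95%.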

Compound 4, a percentage reported as inhibition, in the whole organism at one dose (the size of the read-out at that dose, not a potency) in the Rattus norvegicus assay: 5%
Estimate against measurement, compound 4: 75 percentage points above; the whole stated range lies above it.
By their numbers in the Rattus norvegicus assay, from the lowest: compound 4; then compound 1; then compound 3.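

In the Rattus norvegicus assay, placing 3-methylpyridin-2-yl instead of 2-chloropyridin-3-yl on this aromatic carbon gives a number 87 percentage points lower from compound 3 to compound 4 (beyond the scatter), which shows that the result at this position depends strongly on which pyridinyl group sits there, even though both groups are six-membered aromatic rings with 1 hetero atom and match in heavy atoms, hydrogen-bond donors and hydrogen-bond acceptors. In a physicochemical assay for lipophilicity, read by HPLC, at pH 7.4 (on this read-out lower numbers stand for lower lipophilicity and higher numbers for higher lipophilicity), compound 3 gives -0.5 and compound 4 gives 0.53, so the same change also comes with higher lipophilicity: the measured distribution coefficient of compound 3, -0.5, and of compound 4, 0.53, a number 1.03 log units higher (beyond the scatter) This single pair cannot tell whether that rise in lipophilicity accounts for the fall in the Rattus norvegicus assay, as the two read-outs are seen to move together only once.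

The compounds shown also leave open whether the fall follows the exchange of chlorine for methyl or the different point of attachment of the pyridine ring, as the change from compound 3 to compound 4 alters both at once. A 2-methylpyridin-3-yl or a 3-chloropyridin-2-yl group on the same carbon of the shared core would separate the two.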